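Dimethoxy Substitution on the Aryl Ketone of a Pyrazole Chalcone

This account rests on a few compounds, and the source may have more. Where it says the series, first, only, none or still open, it means among the compounds named here.

Compound 3 `O=C(/C=C/c1cn(-c2ccccc2)nc1-c1cccnc1)c1ccccc1` gives 2000 nM in a functional assay on HCT-116 cells (Homo sapiens) for inhibition, read by sulforhodamine B assay, with a stated time of 72 h (a higher number here means a weaker inhibitor, a lower number a stronger inhibitor), the second highest of the three numbers measured. Compound 1 `O=C(/C=C/c1cn(-c2ccccc2)nc1-c1cccnc1)c1ccsc1` gives 1300 nM, and compound 2 `O=C(/C=C/c1cn(-c2ccccc2)nc1-c1cccnc1)c1c[nH]c2ccccc12` gives 6400 nM. The exchange of the whole ketone-bound group produced a 1.5-fold higher number from compound 1 to compound 3 (0.19 log units; within the scatter), within the scatter, and a 3.2-fold lower number from compound 2 to compound 3 (0.51 log units; beyond the scatter), a modest step. Compound 4 `COc1ccc(OC)c(C(=O)/C=C/c2cn(-c3ccccc3)nc2-c2cccnc2)c1` differs from compound 3 by 2,5-dimethoxyphenyl in place of phenyl on a carbonyl carbon. For the measured compounds named here, no measured step adds substituents to this ring, so only those two whole-group exchanges bear on it, and both were small or modest. A step in this assay of no more than modest size, with no clear direction, is therefore expected. Compound 4 is estimated at 1500 nM, within 500 nM to 5000 nM, an expected step of a 1.3-fold lower number from compound 3 to compound 4 (0.12 log units; within the scatter).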

Compound 4, half-maximal inhibitory concentration: 1000 nM
Compound 4: the middle estimate sits 1.5-fold (0.18 log units) above what was measured, within the range that was stated.
By their numbers in this assay, from the lowest: compounds 4, 1 and 3 (each within the scatter of the next); then compound 2.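

Placing 2,5-dimethoxyphenyl on the carbonyl carbon gives the first view of a substituted ring here, and the two methoxy groups leave the number within the scatter of the plain and thiophene analogues, with a 2.0-fold lower number from compound 3 to compound 4 (0.30 log units; within the scatter) and a 1.3-fold lower number from compound 1 to compound 4 (0.11 log units; within the scatter). Only the exchange with 1H-indol-3-yl is a real step, with a 6.4-fold lower number from compound 2 to compound 4 (0.81 log units; beyond the scatter), the largest in the set. No available evidence accounts for this result. Open, from the compounds shown here alone, is whether one methoxy group alone behaves alike, and whether an amine or a carboxylic acid on this ring would move the number beyond the scatter.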